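Fluoro to dimethylamino: what the two measured compounds suggest

The source may hold more compounds than are shown below. What is called first, only, known or untested is meant among the compounds shown, and "the series" means these compounds.

Measured compounds and values:
compound 1, `O=C(/C=C/C1=Cc2ccccc2OC1)c1ccc(F)cc1`: 65.6%
compound 2, `O=C(/C=C/C1=Cc2ccccc2OC1)c1cccc(Cl)c1`: 51%

Among the measured compounds shown here, in a functional assay on the whole organism for inhibition, with Mus musculus as the target, with a stated time of 1 h, at a dose of 30 mg/kg by the intraperitoneal route (on this read-out higher numbers stand for more inhibition at the one dose given (going by the name of the read-out) and lower numbers for less inhibition), compound 1 gives 65.6%, the higher of the two numbers known. Compound 2 gives 51%; the change to compound 2 is a number 14.6 percentage points lower from compound 1 to compound 2 (beyond the scatter), a step that swaps the substituted ring attached to the carbonyl carbon for a differently substituted one.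

The next compound, compound 3, `CN(C)c1ccc(C(=O)/C=C/C2=Cc3ccccc3OC2)cc1`, keeps the shared core of compound 1 and alters only the substituent on the aromatic ring attached to the carbonyl: dimethylamino in place of fluoro on an aromatic carbon. The group sits on an aromatic carbon of a six-membered aromatic ring of carbon only, para to a large group.

For the measured compounds named here, no measured step covers this particular exchange. Going by the values given here, the only step known, from compound 1 to compound 2, changes both the group and its place on the ring, so it tells little about replacing fluoro with dimethylamino at the same place. The direction of the step in this assay cannot be predicted from these two numbers; a change of either sign, or none beyond the scatter, remains possible, and the range must be wide.

Compound 3 is therefore estimated to give 58%, expected to fall between 30% and 85%. This estimate amounts to an expected step of a number 7.6 percentage points lower from compound 1 to compound 3 (within the scatter).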

Compound 3, a percentage reported as inhibition, in the whole organism at one dose (the size of the read-out at that dose, not a potency): 57.3%
Compound 3: the middle estimate sits 0.7 percentage points above what was measured, and the stated range covers the measured number.
By their numbers in this assay, from the lowest: compounds 2, 3 and 1 (each within the scatter of the next, the first and the last beyond it).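

Swapping fluoro for dimethylamino on an aromatic carbon, para to a large group, gives in this assay a number 8.3 percentage points lower from compound 1 to compound 3 (within the scatter). At this place, then, the single fluorine atom can give way to dimethylamino, with its 3 heavy atoms and 1 hydrogen-bond acceptor, without a change in the read-out that stands clear of the usual spread of repeat measurements. The earlier step, a number 14.6 percentage points lower from compound 1 to compound 2 (beyond the scatter), could not show this, since it changed the group and its place on the ring together, whereas this step changes the group alone. The data shown include no measurement that could explain this result.

The compounds shown leave open whether a primary amine, a carboxylic acid or a methoxy group at this same place would also keep the read-out close to that of compound 1, and whether dimethylamino would do so at another place on the ring. Each number also comes from one dose at one time, and how the read-out would respond to other doses of these compounds remains unknown.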